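The source may hold more compounds than are shown below. What is called first, only, known or untested is meant among the compounds shown, and "the series" means these compounds.

Compound 2 `O=C(/N=C(/NC(=O)c1ccno1)[Se]Cc1ccccc1)c1ccno1` is the starting point of this step. In a functional assay on PC-3 cells (Homo sapiens) for cytotoxicity, read by MTT assay, with a stated time of 72 h (a higher number here means that more compound is tolerated, a lower number that less compound is tolerated), compound 2 gives > 100000 nM, which is a limit of the assay rather than a measured number. Compound 1 `CS/C(=N\C(=O)c1ccno1)NC(=O)c1ccno1` differs from compound 2 only at the carbon with a double bond to nitrogen. In this assay compound 1 gives > 100000 nM, again a limit. Compound 3 `O=C(/N=C(/NC(=O)c1cccs1)[Se]Cc1ccccc1)c1cccs1` differs from compound 2 elsewhere, in the shared core rather than at the selenium-bearing group. In this assay compound 3 gives > 100000 nM, also a limit. For the measured compounds named here, the one step that has been measured, a step that the two limits leave unreadable from compound 1 to compound 2, therefore cannot be read, since both of its ends rest at the limit of > 100000 nM in this assay, at which 3 of the 3 values shown sit. Where compound 2 stands is thus known only as a limit, and the same holds for the two other values.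

Compound 4 `C[Se]/C(=N\C(=O)c1ccno1)NC(=O)c1ccno1` is the next compound: hydrogen in place of phenyl on a saturated chain carbon bound to a selenium atom. Going by the values given here, no measured step has a readable size, and compound 1, which carries the corresponding methylthio group, also sits at its limit. The expected outcome in this assay is therefore no step beyond the scatter, with a step that the limit leaves unreadable from compound 2 to compound 4 expected. Compound 4 is estimated at 150000 nM, with a range from 40000 nM to 500000 nM, most likely reported again only as a limit.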

Compound 4, concentration lethal to 50% of the cells: > 100000 nM
Compound 4 ended at the assay's limit; the forecaster's own chance of this, stated with the estimate: 80%; the middle value does not contradict the limit.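

Compound 4 also rests at a limit in this assay, so neither its step from compound 2 nor its step from compound 1 can be read: the limit of > 100000 nM in this assay, at which 4 of the 4 values shown sit.

The compounds shown leave open whether benzyl to methyl, or selenium in place of sulfur, makes any difference in this assay, where none of them gives a value that is more than a limit.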